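A longer ether-linked selenocyanate chain on the shared core

A few compounds are considered here, and "the series" means these few. Any claim that something is new, unique, unknown or untested is made for them only; others in the source may bear on it.

Going by the values given here, compound 2 `COc1ccc(N(C)c2nc(C)nc3ccccc23)cc1C(=O)NCC[Se]C#N` is one of three compounds measured in a functional assay on HCT-116 cells (Homo sapiens) for inhibition, read by MTT assay, with a stated time of 48 h; a higher number here means a weaker inhibitor, a lower number a stronger inhibitor. In this assay compound 2 gives 313 nM, the second highest of the three numbers. Its nearest neighbour is compound 3 `COc1ccc(N(C)c2nc(C)nc3ccccc23)cc1C(=O)OCCCCC[Se]C#N`, which gives 551 nM, while the furthest is compound 1 `Cc1nc(N(C)c2ccc([Se]C#N)c(Cl)c2)c2ccccc2n1`, which gives 12 nM and stands well beyond the scatter from compound 2.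

Compound 4 `COc1ccc(N(C)c2nc(C)nc3ccccc23)cc1OCCCCC[Se]C#N` has not yet been measured. It differs from compound 2 as follows: a group of 9 heavy atoms (6 carbon, 1 nitrogen, 1 oxygen, 1 selenium; no ring) in place of a group of 8 heavy atoms (4 carbon, 2 nitrogen, 1 oxygen, 1 selenium; no ring), on an aromatic carbon. The group that enters is the same six-carbon chain carrying a selenium and a nitrile that enters in compound 3, but here it sits directly on an aromatic carbon of the ring, ortho to a methoxy group, rather than on a carbonyl carbon.

Among the compounds with values here, one measured step bears on this change: a 1.8-fold higher number from compound 2 to compound 3 (0.25 log units; within the scatter). That step, which also swapped a short amide-bound selenocyanate chain for the longer chain, stayed within the scatter. The step to compound 4 is therefore expected to be small as well, with a slight tendency toward a higher number, as a 1.3-fold higher number from compound 2 to compound 4 (0.13 log units; within the scatter) expresses. Compound 4 is accordingly estimated to give 420 nM in this assay, with a likely range from 150 nM to 1200 nM.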

Compound 4, half-maximal inhibitory concentration: 256 nM
Compound 4: the middle estimate sits 1.6-fold (0.22 log units) above what was measured; low and high end bracket the measured number.
By their numbers in this assay, from the lowest: compound 1; then compounds 4, 2 and 3 (each within the scatter of the next, the first and the last beyond it).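

In this assay the exchange on this aromatic carbon, ortho to a methoxy group, amounts to a 1.2-fold lower number from compound 2 to compound 4 (0.09 log units; within the scatter) and shows that the group of 9 heavy atoms can take the place of the group of 8 heavy atoms without a step beyond the scatter. The earlier step, a 1.8-fold higher number from compound 2 to compound 3 (0.25 log units; within the scatter), kept a carbonyl on the ring, whereas this one removes both that carbonyl and the amide hydrogen, so for compounds 2 and 4 neither feature is needed to keep the number within the scatter. Nothing available here accounts for this lack of a clear difference at this position.

The compounds shown leave open how the number responds to a shorter or a longer chain on the ether oxygen, since only one chain is shown in this form. They also leave open what happens when the selenium and nitrile at the chain end give way to an amine or a carboxylic acid, or when the methoxy group is replaced by a hydrogen or an ethoxy group.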